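Azonafide-like core: replacing the imidazolyl chain with pyrrolidine

A few compounds are considered here, and "the series" means these few. Any claim that something is new, unique, unknown or untested is made for them only; others in the source may bear on it.

Among the measured compounds shown here, compound 1 `O=C1c2c[n+]([O-])c3ccccc3c2C(=O)c2c1c1ccccc1n2CCCCn1ccnc1` is the lowest of the two numbers measured so far: in a functional assay on A549 cells (Homo sapiens) for cytotoxicity, read by MTT assay, with a stated time of 72 h (on this read-out higher numbers stand for weaker inhibition and lower numbers for stronger inhibition), compound 1 gives 170 nM. Compound 2 `O=C1c2c[n+]([O-])c3ccccc3c2C(=O)c2c1c1ccccc1n2Cc1cn(CC(O)CO)nn1` in this assay gives 880 nM, and the step of a 5.2-fold higher number from compound 1 to compound 2 (0.71 log units; beyond the scatter) shows that changing the group on the chain carbon bound to the aromatic nitrogen costs activity. Compound 3 `O=C1c2c[n+]([O-])c3ccccc3c2C(=O)c2c1c1ccccc1n2CCN1CCCC1` carries the change (pyrrolidin-1-yl in place of 2-(1H-imidazol-1-yl)ethyl on a saturated chain carbon, two bonds along the chain from an aromatic nitrogen). For the measured compounds named here, only the step from compound 1 to compound 2 bears on this, and it was modest, so a small loss is expected, within or just beyond the scatter. Compound 3 is therefore estimated at 300 nM, range 100 nM to 900 nM, meaning an expected step of a 1.8-fold higher number from compound 1 to compound 3 (0.25 log units; within the scatter).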

Compound 3, half-maximal inhibitory concentration: 410 nM
Beside the measured number, compound 3's estimate is 1.4-fold (0.14 log units) below it; measured number inside the range.
By their numbers in this assay, from the lowest: compound 1; then compound 3; then compound 2.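

In this assay, pyrrolidin-1-yl in place of 2-(1H-imidazol-1-yl)ethyl gives a 2.4-fold higher number from compound 1 to compound 3 (0.38 log units; beyond the scatter), so at this place on the chain a non-aromatic ring end does not match the imidazole end of compound 1. Set against the triazole side chain, (pyrrolidin-1-yl)methyl gives a 2.1-fold lower number from compound 2 to compound 3 (0.33 log units; beyond the scatter), which puts the pyrrolidine end in the middle of the three. No measurement on hand accounts for either step.

As far as these compounds go, whether the ring or the chain length carries the lead of compound 1 stays open. So does the effect of a 4-(pyrrolidin-1-yl)butyl chain or a dimethylamino end.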